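Cyclopentyl for Isopropyl on the Amide of Compound 2

The source may report more compounds than this note shows. Statements on the series, on what has been measured and on what is new or still open speak of the compounds shown alone.

Compound 1 `Cc1cc(C(=O)Nc2cccc(F)c2)nn1Cc1cc(Cl)ccc1OCc1ccccc1`: 200 nM
Compound 2 `Cc1cc(NC(=O)C(C)C)nn1Cc1cc(Cl)ccc1OCc1ccccc1`: 25.1 nM

Both compounds were tested in an assay on CHO-K1 cells for displacement of a labelled ligand from prostaglandin E2 receptor EP1 subtype (Homo sapiens); a higher number here means a weaker inhibitor, a lower number a stronger inhibitor. In this assay compound 1 gives 200 nM. Compound 2 gives 25.1 nM and so stands as the lower of the two numbers. Going by the values given here, the single measured step, an 8.0-fold lower number from compound 1 to compound 2 (0.90 log units; beyond the scatter), comes from replacing the (3-fluorophenyl)carbamoyl group with (isopropylcarbonyl)amino on the shared core, a change at the same amide position but of a different kind from the one now considered.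

Compound 3 `Cc1cc(NC(=O)C2CCCC2)nn1Cc1cc(Cl)ccc1OCc1ccccc1` differs from compound 2 in one place: cyclopentyl in place of isopropyl on a carbonyl carbon. The measured step bears on it only indirectly, by showing that the number responds to what is attached at this amide; it does not show how the size of the acyl group alone matters. The step from compound 2 to compound 3 is therefore expected to stay within the scatter, with at most a slight lowering: a 1.4-fold lower number from compound 2 to compound 3 (0.14 log units; within the scatter). Compound 3 is estimated at 18 nM, within a range of 6 nM to 55 nM.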

Compound 3, half-maximal inhibitory concentration: 15.9 nM
Compound 3: the middle estimate sits 1.1-fold (0.05 log units) above what was measured; the measured number falls inside the stated range.
By their numbers in this assay, from the lowest: compounds 3 and 2 (each within the scatter of the next); then compound 1.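

In this assay, the acyl group on this amide can be enlarged from isopropyl to cyclopentyl, which brings in a five-membered non-aromatic ring of carbon only, with a 1.6-fold lower number from compound 2 to compound 3 (0.20 log units; within the scatter) and so without any change that this read-out can separate from scatter. This shows that the position accepts a carbon ring on the carbonyl carbon as well as the open isopropyl group, something the earlier pair could not show. The gap to the (3-fluorophenyl)carbamoyl compound also holds with the new group, as a 13-fold lower number from compound 1 to compound 3 (1.10 log units; beyond the scatter) shows, so it is not tied to (isopropylcarbonyl)amino alone. Nothing given here accounts for either step.

The compounds shown leave open how far this tolerance runs, since only isopropyl and cyclopentyl are compared on this carbonyl carbon, and a cyclohexyl ring, a longer chain such as n-butyl or a terminal amine could behave differently. They also leave open whether a carboxylic acid in place of the acyl group's carbon ring would keep the number in this assay or raise it beyond the scatter.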